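The source may hold more compounds than are shown below. What is called first, only, known or untested is meant among the compounds shown, and "the series" means these compounds.

Measured so far:
compound 1 `O=C(Nc1ccc(Cl)cc1)NS(=O)(=O)c1cccs1` — 16%
compound 2 `COc1csc(S(=O)(=O)NC(=O)Nc2ccc(Cl)cc2)c1` — 36%

Notes on the series. In a functional assay on the whole organism (6C3HED cells, Mus musculus) for inhibition, at a dose of 150 mg/kg by the oral route (on this read-out lower numbers stand for less inhibition and higher numbers for more inhibition at the one dose given (going by the name of the read-out)), compound 1 gives 16%, and compound 2 gives 36%. Within the data shown here, the one measured step is a number 20 percentage points higher from compound 1 to compound 2 (beyond the scatter). On these two numbers compound 2 stands highest, its nearest neighbour being compound 1, which lies lower by a step beyond the scatter.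

Compound 3 `O=C(Nc1ccc(Cl)cc1)NS(=O)(=O)c1cc(Br)c(Br)s1` is not yet measured. It differs from compound 2 thus: 4,5-dibromothiophen-2-yl in place of 4-methoxythiophen-2-yl on a sulfonyl sulfur. Among the measured compounds shown here, no measured step bears directly on this change: the single step from compound 1 to compound 2 concerns a methoxy in place of hydrogen on an aromatic carbon, whereas here the 4-methoxythiophen-2-yl leaves altogether and a 4,5-dibromothiophen-2-yl enters on the sulfonyl sulfur. What that step shows is only that a substituent on this ring moved the read-out by a modest amount; it does not say whether two bromines in place of a methoxy will do the same. The expected step, a number 8 percentage points lower from compound 2 to compound 3 (within the scatter), is therefore small and uncertain in direction, and compound 3 is estimated at 28% in this assay, within 5% to 55%.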

Compound 3, a percentage reported as inhibition, in the whole organism at one dose (the size of the read-out at that dose, not a potency): 25%
Compound 3: the middle estimate sits 3 percentage points above what was measured; the range from low to high includes it.
By their numbers in this assay, from the lowest: compounds 1 and 3 (each within the scatter of the next); then compound 2.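

Working from this assay, 4,5-dibromothiophen-2-yl on the sulfonyl sulfur gives a number 11 percentage points lower from compound 2 to compound 3 (beyond the scatter), so at this position the dibromo ring does not match the ring carrying the methoxy. Set against the plain ring, the same change gives a number 9 percentage points higher from compound 1 to compound 3 (within the scatter), whereas the methoxy step is a number 20 percentage points higher from compound 1 to compound 2 (beyond the scatter), so among these three compounds a substituted ring alone does not separate a compound from the plain thiophen-2-yl, and only compound 2 stands apart from the other two. Nothing available on these compounds accounts for the difference between the methoxy and dibromo rings.

As far as these compounds go, whether a longer ether such as ethoxy, or an amine or a carboxylic acid on the same ring, would match the methoxy stays open, and so does what each bromine contributes on its own. These figures also come from a single oral dose, so they give the size of the read-out at that dose and leave the ranking of the compounds at other doses unsettled.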